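Fluorine on the Phenylpiperazine Across Two Related Cores

This account rests on a few compounds, and the source may have more. Where it says the series, first, only, none or still open, it means among the compounds named here.

Measured so far:
Compound 1, `C/C1=C\CC[C@@]2(C)O[C@@H]2[C@H]2OC(=O)[C@@H](CN3CCN(c4ccccc4)CC3)[C@@H]2C[C@H]1O`: 19000 nM
Compound 2, `C/C1=C\CC[C@@]2(C)O[C@@H]2[C@H]2OC(=O)[C@@H](CN3CCN(c4ccccc4F)CC3)[C@@H]2C[C@H]1O`: 25000 nM
Compound 3, `C[C@]12O[C@@H]1CC[C@@]1(C)O[C@@H]1[C@H]1OC(=O)[C@@H](CN3CCN(c4ccccc4)CC3)[C@@H]1C[C@H]2O`: 51000 nM

Of the compounds shown here, three have been tested in a functional assay on SK-MEL-28 cells (Homo sapiens) for inhibition, read by MTT assay, with a stated time of 72 h; a higher number here means a weaker inhibitor, a lower number a stronger inhibitor. Compound 1 and compound 2 share one core and differ by fluoro in place of hydrogen on an aromatic carbon; this change gave a 1.3-fold higher number from compound 1 to compound 2 (0.12 log units; within the scatter). Compound 3 carries a second core; the difference between the two cores is not broken down here. In this assay compound 3 gives the highest of the three numbers, and its distance to both compound 1 and compound 2 lies beyond the usual scatter of repeated measurements.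

Compound 4, `C[C@]12O[C@@H]1CC[C@@]1(C)O[C@@H]1[C@H]1OC(=O)[C@@H](CN3CCN(c4ccccc4F)CC3)[C@@H]1C[C@H]2O`, has not yet been measured. It stands to compound 3 as compound 2 stands to compound 1: it differs by fluoro in place of hydrogen on an aromatic carbon, which is the same change made once more on the other core. Because a 1.3-fold higher number from compound 1 to compound 2 (0.12 log units; within the scatter) was within the scatter, the same change on compound 3 is expected to move the number little, and compound 4 is expected to sit close to compound 3, with a step of about a 1.2-fold higher number from compound 3 to compound 4 (0.07 log units; within the scatter). In this assay compound 4 is therefore expected to give roughly 60000 nM, most likely between 30000 nM and 120000 nM. Within the data shown here, this expectation rests only on the single earlier pair, so a larger deviation cannot be ruled out.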

Compound 4, half-maximal inhibitory concentration: 17000 nM
Compound 4: the middle estimate sits 3.5-fold (0.55 log units) above what was measured, and the stated range ends above it.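

In this assay, the change from phenyl to 2-fluorophenyl on the second core gave a 3.0-fold lower number from compound 3 to compound 4 (0.48 log units; beyond the scatter) and so did not repeat what the same change had done on the core of compound 1, and the two steps stand further apart than repeated measurement would account for: the same change on two cores in this assay, a 1.3-fold higher number (0.12 log units; within the scatter) from compound 1 to compound 2 and a 3.0-fold lower number (0.48 log units; beyond the scatter) from compound 3 to compound 4, 3.9-fold (0.60 log units) apart, beyond the scatter of two such steps.
Within this series, then, the result of this change on one core could not be carried over to the other, and the fluoro group has to be judged on each core separately. Among these compounds, with only one pair on each core, this does not show how general the difference is or what lies behind it, and it gives no rule for any other change made on these two cores.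

The compounds shown leave open whether chloro or methoxy, placed on the same aromatic carbon, would part in the same way between the two cores or would give matching steps on both. They also leave open whether the gap between the two steps would persist if the phenylpiperazine gave way to another amine, such as morpholine.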